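The source may report more compounds than this note shows. Statements on the series, on what has been measured and on what is new or still open speak of the compounds shown alone.

Compound 1 `O=C(/C=C/c1ccccc1F)c1ccc(O)cc1` is a small molecule tested in a functional assay on RAW264.7 cells (Mus musculus) for inhibition, read by fluorescence, with stated times of 1 h, 24 h and 30 min; on this read-out higher numbers stand for weaker inhibition and lower numbers for stronger inhibition. In this assay compound 1 gives > 10000 nM, which is a limit of the assay and not a number. Compound 2 `O=C(/C=C/c1ccc(F)cc1)c1ccccc1` gives > 10000 nM, also a limit. Compound 3 `O=C(/C=C/c1ccc(F)cc1)c1ccc(O)cc1` gives > 10000 nM, again a limit. Taken together, these results show (the limit of > 10000 nM in this assay, at which 3 of the 3 values shown sit), so the position of compound 1 among its neighbours cannot be ranked.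

The next compound, compound 4 `O=C(/C=C/c1ccccc1C(F)(F)F)c1ccc(O)cc1`, changes one group of compound 1: trifluoromethyl in place of fluoro on an aromatic carbon. In words, trifluoromethyl takes the place of fluoro on an aromatic carbon.

Among the measured compounds shown here, only one measured step exists to compare with, a step that the two limits leave unreadable from compound 2 to compound 3. It concerns hydroxy in place of hydrogen, not this swap, and it has no readable size. For the measured compounds named here, no measured pair shows fluoro replaced by trifluoromethyl, so the data offer no size or direction to carry over.

The expectation therefore rests on compound 1, whose > 10000 nM is a limit. The expected change is small and of uncertain direction, and the estimated step is a step that the limit leaves unreadable from compound 1 to compound 4. A reported limit is also a likely outcome. The estimate for compound 4 is 15000 nM, with an expected range from 5000 nM to 40000 nM.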

Compound 4, half-maximal inhibitory concentration: > 10000 nM
Compound 4 was reported as a limit; the forecaster's own chance of this, stated with the estimate: 70%; the middle value lies beyond the limit too.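

Compound 1 and compound 4 are both reported only as limits in this assay, so no step can be read for trifluoromethyl in place of fluoro. The compounds shown leave open how strongly any of them inhibits and whether this swap changes inhibition at all, because every result sits at one boundary: the limit of > 10000 nM in this assay, at which 4 of the 4 values shown sit.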